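Methylsulfanyl for hydroxy on the shared core of compound 1

This account rests on a few compounds, and the source may have more. Where it says the series, first, only, none or still open, it means among the compounds named here.

Compound 1 `Cc1cc(O)nc(NC(=S)NC(=O)c2c(-c3ccc(Cl)cc3Cl)noc2C)n1` gives -5.86% in a functional assay on the whole organism for inhibition, with Chenopodium ficifolium as the target, with a stated time of 72 h, tested at 10 mg/L (on this read-out higher numbers stand for more inhibition of growth at the one concentration tested and lower numbers for less inhibition of growth), the lowest of the two numbers in hand. Going by the values given here, compound 2 `COc1cc(C)nc2n/c(=N/C(=O)c3c(-c4ccc(Cl)cc4Cl)noc3C)sn12` gives 45.7%, a figure well beyond the scatter above compound 1, though no single-point step between the two is defined. Compound 3 `CSc1cc(C)nc(NC(=S)NC(=O)c2c(-c3ccc(Cl)cc3Cl)noc2C)n1` differs from compound 1 by methylsulfanyl in place of hydroxy on an aromatic carbon. Among the compounds with values here, with no measured step of this kind to lean on, the expected change from compound 1 to compound 3 is a number 15.9 percentage points higher from compound 1 to compound 3 (beyond the scatter), a modest gain not clearly beyond the scatter. Compound 3 is therefore estimated at 10%, within -10% to 35%.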

Compound 3, percent growth inhibition at one concentration: 32.8%
Beside the measured number, compound 3's estimate is 22.8 percentage points below it; the range from low to high includes it.
By their numbers in this assay, from the lowest: compound 1; then compound 3; then compound 2.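

Going by these compounds alone, this position on the shared core is sensitive to its substituent: in this assay, methylsulfanyl in place of hydroxy gives a number 38.7 percentage points higher from compound 1 to compound 3 (beyond the scatter) and is the first single-place change that can be read. This large step comes from one exchange at the carbon next to the ring nitrogen, with the rest of compound 1 unchanged. Nothing in hand explains the step.

As far as these compounds go, whether the gain follows from losing hydroxy or from gaining methylsulfanyl remains open. An amine or ethylsulfanyl at this position would help separate the two.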